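Ethoxy for cyclopropyl on the fused core: compound 3

This account rests on a few compounds, and the source may have more. Where it says the series, first, only, none or still open, it means among the compounds named here.

Measured so far:
compound 1 `Fc1cc2[nH]ncc2cc1-c1ccccc1C(F)(F)F` — 48 nM
compound 2 `FC(F)(F)c1ccccc1-c1cc2cn[nH]c2cc1C1CC1` — 61 nM

In an assay on CHO-TREX cells for antagonist activity at transient receptor potential cation channel subfamily A member 1 (Homo sapiens), read by FLIPR and calcium flux, with a stated time of 10 min (a lower number here means a stronger inhibitor, a higher number a weaker inhibitor), compound 1 gives 48 nM and compound 2 gives 61 nM. Within the data shown here, of the two numbers, that of compound 2 is the one nearer the top, though the single step of a 1.3-fold higher number from compound 1 to compound 2 (0.10 log units; within the scatter) lies within the scatter. Compound 3 `CCOc1cc2[nH]ncc2cc1-c1ccccc1C(F)(F)F` differs from compound 2 by ethoxy in place of cyclopropyl on an aromatic carbon. Among the measured compounds shown here, the one measured step bears on it only by showing that exchange at this position has so far left this assay without a shift beyond the scatter. The step to compound 3 is therefore expected to be small, a 1.3-fold higher number from compound 2 to compound 3 (0.12 log units; within the scatter), or none beyond the scatter. Compound 3 is expected at 80 nM, range 30 nM to 250 nM.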

Compound 3, half-maximal inhibitory concentration: 39 nM
Compound 3: middle estimate off by 2.1-fold (0.31 log units), on the high side; measured number inside the range.
By their numbers in this assay, from the lowest: compounds 3, 1 and 2 (each within the scatter of the next).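

In this assay the position takes ethoxy as well as cyclopropyl or fluoro: ethoxy in place of cyclopropyl gives a 1.6-fold lower number from compound 2 to compound 3 (0.19 log units; within the scatter), and ethoxy in place of fluoro gives a 1.2-fold lower number from compound 1 to compound 3 (0.09 log units; within the scatter). An open chain holding an oxygen thus reads level with a three-membered carbon ring and with fluoro, so the range of groups without a shift beyond the scatter is wider than the first step showed. No measured property of these groups bears on this result.

Open, from the compounds shown here alone, is how an amine, a carboxylic acid or a longer chain such as butoxy would read at this position, and whether any group here moves the number beyond the scatter.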